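The compounds below may be only part of what the source reports. "The series", "measured", "known", "first", "only" and "open" are said of these compounds alone.

Compound 1 `CC#C[C@@H](CC(=O)O)c1ccc(OCc2ccc3nc(-c4ccc(OC(F)F)cc4)nn3c2)cc1` and compound 2 `CC#C[C@@H](CC(=O)O)c1ccc(OCc2ccc3nc(-c4c(C)cc(OCCCS(C)(=O)=O)cc4C)nn3c2)cc1` share one core and differ only in the aryl substitution at its far end. In an assay on HEK293 cells for displacement of a labelled ligand from Free fatty acid receptor 1 (Homo sapiens), read by scintillation counting, with a stated time of 2 h (a lower number here means a stronger inhibitor, a higher number a weaker inhibitor), compound 1 gives 60 nM, and in this assay compound 2 gives 63 nM, so the two values sit within the scatter of each other. Compound 3 `CC#C[C@@H](CC(=O)O)c1ccc(OCc2ccc3nc(-c4ccc(C(C)C)cc4)nn3c2)cc1` is derived from compound 1 by a single change: isopropyl in place of difluoromethoxy on an aromatic carbon. Going by the values given here, no measured pair shows such a step, so its size is unknown. Compound 3 is expected to stay close to compound 1, with a step of a 1.3-fold higher number from compound 1 to compound 3 (0.12 log units; within the scatter) that lies within the scatter, and its estimated value is 80 nM, in the range 30 nM to 250 nM.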

Compound 3, inhibition constant: 32 nM
For compound 3 the middle estimate is 2.5-fold (0.40 log units) above the measured one; the range from low to high includes it.
By their numbers in this assay, from the lowest: compounds 3, 1 and 2 (each within the scatter of the next).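

In this assay, isopropyl in place of difluoromethoxy gives a 1.9-fold lower number from compound 1 to compound 3 (0.27 log units; within the scatter) and so stays within the scatter. At this aromatic carbon, para to a large group, an all-carbon group therefore serves as well as one holding oxygen and fluorine. No evidence here bears on why the two groups read alike. From the compounds shown here alone, what an amine, a carboxylic acid or a longer chain would give at this carbon stays open. So does whether any group here can move the value beyond the scatter.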